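The source may hold more compounds than are shown below. What is called first, only, known or untested is meant among the compounds shown, and "the series" means these compounds.

Series notes. The shared core carries a methylpyrazole bearing a benzyloxy-chlorobenzyl group; the compounds differ in what sits on the remaining aromatic carbon. Compound 1 `Cc1cc(C(=O)NCc2ccccn2)nn1Cc1cc(Cl)ccc1OCc1ccccc1` and compound 2 `Cc1cc(C(=O)NCc2ccncc2)nn1Cc1cc(Cl)ccc1OCc1ccccc1` carry pyridylmethyl carbamoyl groups; compound 3 `Cc1cc(NC(=O)CC2CCCCC2)nn1Cc1cc(Cl)ccc1OCc1ccccc1` carries a ((cyclohexylmethyl)carbonyl)amino group.

In a physicochemical assay for lipophilicity, at pH 7.4 (a lower number here means a more polar compound, a higher number a more lipophilic compound), compound 1 gives > 3.7, which is a limit of the assay and not a number. In this assay compound 2 likewise gives > 3.7, again a limit. Among the measured compounds shown here, compound 3 is the only compound with a number, giving 3.2 in this assay. The step of a number at least 0.50 log units lower from compound 1 to compound 3 (beyond the scatter) and the step of a number at least 0.50 log units lower from compound 2 to compound 3 (beyond the scatter) are both readable only as lower bounds, since (the limit of > 3.7 in this assay, at which 2 of the 3 values shown sit); the step that the two limits leave unreadable from compound 1 to compound 2 is not readable at all.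

Compound 4 `Cc1cc(NC(=O)OCC(C)C)nn1Cc1cc(Cl)ccc1OCc1ccccc1` is not yet measured. It differs from compound 3 by isobutoxy in place of cyclohexylmethyl on a carbonyl carbon. For the measured compounds named here, no measured step changes the group on this carbonyl carbon, so the measured steps do not bear directly on it; they only place compound 3 as the single fixed point. On the counted difference alone, the leaving group has 7 heavy atoms of carbon and the entering group 5 heavy atoms with one acceptor, so a modest decrease is expected.

Compound 4 is estimated at 2.7 in this assay, within 2.2 to 3.2. The expected step is a number 0.50 log units lower from compound 3 to compound 4 (beyond the scatter).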

Compound 4, distribution coefficient: 3.3
The estimate for compound 4 lay 0.60 log units below the measured number, and the stated range ends below it.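

In this assay, isobutoxy in place of cyclohexylmethyl on a carbonyl carbon gives a number 0.10 log units higher from compound 3 to compound 4 (within the scatter), so this position now has its first measured step, and losing the six-membered non-aromatic ring while gaining an oxygen leaves the reading within the scatter. On the aromatic carbon, (isobutoxycarbonyl)amino in place of ((pyridin-4-yl)methyl)carbamoyl gives a number at least 0.40 log units lower from compound 2 to compound 4 (beyond the scatter), and in place of ((pyridin-2-yl)methyl)carbamoyl it gives a number at least 0.40 log units lower from compound 1 to compound 4 (beyond the scatter), so a second, differently built group on this carbon now also stands beyond the scatter from the pyridylmethyl carbamoyl compounds. These two steps remain lower bounds and the step between the two pyridylmethyl carbamoyl compounds cannot be read, because those compounds sit at an assay limit: the limit of > 3.7 in this assay, at which 2 of the 4 values shown sit.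

As far as these compounds go, whether the flat reading at this carbonyl carbon extends beyond these two groups stays open, since a group carrying a tertiary amine or a carboxylic acid in place of isobutoxy would test it on a different kind of substituent. The compounds shown also leave open how far the reversed linkage and the end group each count on the aromatic carbon, which a cyclohexylmethyl carbamoyl group would separate.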